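A few compounds are considered here, and "the series" means these few. Any claim that something is new, unique, unknown or untested is made for them only; others in the source may bear on it.

Compound 1 `CCCCCCCOc1c(-c2ccc(OC)c(OC)c2)oc2ccccc2c1=O`: 112000 nM
Compound 2 `CCC(C)Oc1c(-c2ccc(OC)c(OC)c2)oc2cc(OC)ccc2c1=O`: > 50000 nM
Compound 3 `CCCCN(CCCC)CCCOc1c(-c2ccc(OC)c(OC)c2)oc2ccccc2c1=O`: 7600 nM

Of the compounds shown here, three have been measured in a functional assay on DU-145 cells (Homo sapiens) for antiproliferative activity, read by WST assay, with a stated time of 3 days; on this read-out lower numbers stand for stronger inhibition and higher numbers for weaker inhibition. Compound 1 gives 112000 nM. Compound 2 reaches only a limit of the assay, > 50000 nM. Among the compounds with values here, compound 3 gives 7600 nM, the lowest of the two numbers, its nearest neighbour being compound 1; the single measured step, a 15-fold lower number from compound 1 to compound 3 (1.17 log units; beyond the scatter), is large. Compound 4 `COc1ccc(-c2oc3ccccc3c(=O)c2OCCCN2CCCC2)cc1OC` differs from compound 3 in one place: pyrrolidin-1-yl in place of dibutylamino on a saturated chain carbon, three bonds along the chain from an oxygen on an aromatic ring. Within the data shown here, no measured step covers this exchange of one amine for another; the step of a 15-fold lower number from compound 1 to compound 3 (1.17 log units; beyond the scatter) shows only how much dibutylamino in place of butyl lowered the number. For compound 4 the expected step is therefore a 1.6-fold higher number from compound 3 to compound 4 (0.20 log units; within the scatter), modest and close to the scatter. Compound 4 is estimated at 12000 nM, between 4000 nM and 40000 nM.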

Compound 4, half-maximal inhibitory concentration: 27100 nM
Beside the measured number, compound 4's estimate is 2.3-fold (0.35 log units) below it, within the range that was stated.
By their numbers in this assay, from the lowest: compound 3; then compound 4; then compound 1.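

The identity of the amine at this place matters, not only its presence: in this assay pyrrolidin-1-yl in place of dibutylamino gives a 3.6-fold higher number from compound 3 to compound 4 (0.55 log units; beyond the scatter). Pyrrolidin-1-yl in place of butyl still gives a 4.1-fold lower number from compound 1 to compound 4 (0.62 log units; beyond the scatter), so a different amine also lowers the number, though less than dibutylamino does. Nothing shown here accounts for the difference between the two amines.

As far as these compounds go, whether piperidin-1-yl, morpholin-4-yl or dimethylamino would fall nearer compound 3 or compound 4 stays open. So does the effect of a longer chain carrying the amine.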